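Trading a Furan for a Thiazole on the Shared Core

This account rests on a few compounds, and the source may have more. Where it says the series, first, only, none or still open, it means among the compounds named here.

Compound 2 `Cc1ccoc1-c1ccccc1OCC1=NCCN1` carries a 3-methylfuran-2-yl group on the shared core. In a functional assay for activation of Alpha-1D adrenergic receptor (Homo sapiens), read by calcium flux (a lower number here means that less compound is needed, a higher number that more compound is needed for the effect), compound 2 gives only a limit, < 100000 nM, and no number. Compound 3 `Cc1csc(-c2ccccc2OCC2=NCCN2)n1` differs from it in one place: 4-methyl-1,3-thiazol-2-yl in place of 3-methylfuran-2-yl on an aromatic carbon. Within the data shown here, no measured step runs between a furan and a thiazole here. Among the measured compounds shown here, the only measured step, a step that the limit leaves unreadable from compound 1 to compound 2, has its size hidden by the limit (the limit of < 100000 nM in this assay, at which 1 of the 2 values shown sits). Compound 1 `c1c[nH]c(-c2ccccc2OCC2=NCCN2)c1` gives 6.31 nM in this assay. With so little to lean on, the estimated step is a step that the limit leaves unreadable from compound 2 to compound 3. Compound 3 is expected to give about 1500 nM, within 50 nM to 40000 nM.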

Compound 3, half-maximal effective concentration: < 100000 nM
Compound 3 gave a limit, no number (the forecaster's own chance of this, stated with the estimate: 40%); the middle value lies beyond the limit too.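

No step can be read among compound 1, compound 2 and compound 3: compound 2 and compound 3 each give only a limit, not a number, in this assay. On these data alone, whether compound 2 and compound 3 differ from each other, and how far either lies from compound 1, stays open.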